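Swapping methoxy for trifluoromethyl in compound 3

A few compounds are considered here, and "the series" means these few. Any claim that something is new, unique, unknown or untested is made for them only; others in the source may bear on it.

Of the compounds shown here, three sharing one core have been tested so far in a functional assay on MDA-MB-231 cells (Homo sapiens) for antiproliferative activity, with a stated time of 4 days; a higher number here means a weaker inhibitor, a lower number a stronger inhibitor. There, compound 1 `CCCCc1ccc2[nH]c(-c3ccc(C(F)(F)F)cc3)c(/C=N/NC(=O)c3ccc(Cl)cc3)c2c1` gives 329 nM, compound 2 `CCCCc1ccc2[nH]c(-c3ccc(C(F)(F)F)cc3)c(/C=N/NC(=O)c3ccc(OC)cc3)c2c1` gives 284 nM, and compound 3 `CCCCc1ccc2[nH]c(-c3ccc(OC)cc3)c(/C=N/NC(=O)c3ccc([N+](=O)[O-])cc3)c2c1` gives 115 nM. Compound 3 has the lowest number of the three, and its gap to each of the others lies beyond the scatter.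

The next compound, compound 4 `CCCCc1ccc2[nH]c(-c3ccc(C(F)(F)F)cc3)c(/C=N/NC(=O)c3ccc([N+](=O)[O-])cc3)c2c1`, differs from compound 3 in one place: trifluoromethyl in place of methoxy on an aromatic carbon. In words, this is trifluoromethyl in place of methoxy on an aromatic carbon, para to a large group.

Among the measured compounds shown here, only one measured step is available, a 1.2-fold lower number from compound 1 to compound 2 (0.06 log units; within the scatter). It lies within the scatter, but it sits at a different place in the molecule, so it says little directly about this swap. More useful is that compound 1 at 329 nM and compound 2 at 284 nM already carry the trifluoromethyl group. Compound 3 at 115 nM stands lower than both, but both also differ from it in a second place, so the data cannot separate the two changes.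

A moderate rise in the number is therefore expected in this assay, a 1.9-fold higher number from compound 3 to compound 4 (0.28 log units; within the scatter). Compound 4 is estimated at 220 nM, with an expected range of 100 nM to 480 nM.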

Compound 4, half-maximal inhibitory concentration: 2040 nM
Compound 4: middle estimate off by 9.3-fold (0.97 log units), on the low side, outside the stated range (above it).
By their numbers in this assay, from the lowest: compound 3; then compounds 2 and 1 (each within the scatter of the next); then compound 4.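

In this assay, the group at this aromatic carbon, para to a large group, turns out to matter a great deal: trifluoromethyl in place of methoxy gives a large step (an 18-fold higher number from compound 3 to compound 4 (1.25 log units; beyond the scatter)). With trifluoromethyl held in place, the substituent on the far ring also matters, since nitro in place of methoxy gives a modest step (a 7.2-fold higher number from compound 2 to compound 4 (0.86 log units; beyond the scatter)), as does nitro in place of chloro (a 6.2-fold higher number from compound 1 to compound 4 (0.79 log units; beyond the scatter)), while the earlier swap of methoxy for chloro stayed within the scatter (a 1.2-fold lower number from compound 1 to compound 2 (0.06 log units; within the scatter)); nitro therefore does not bring a low number on its own, and the low number of compound 3 depends on the methoxy that accompanies it. Nothing available here accounts for the size of these steps.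

From the compounds shown here alone, only methoxy and trifluoromethyl appear at this position, so how a hydroxyl group, an amine or a chlorine there would read remains open. Methoxy on this ring is also paired with nitro alone, so whether it would lower the number as much alongside a chloro or methoxy on the far ring is unknown.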